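The compounds below may be only part of what the source reports. "The series", "measured", "known", "first", "only" and "open" are said of these compounds alone.

Compound 1 `CC1=C(C(=O)OC(C)(C)C)C(c2ccsc2)NC(=O)N1` gives 47% in an assay on membranes from HEK293 cells for displacement of a labelled ligand from adenosine receptor A2b (Homo sapiens), read by scintillation counting, with a stated time of 30 min, tested at 1 uM (on this read-out lower numbers stand for less inhibition and higher numbers for more inhibition at the one concentration tested (going by the name of the read-out)), the highest of the three numbers recorded; compound 2 `CC1=C(C(=O)OCc2ccccc2)C(c2ccsc2)NC(=O)N1` gives 44%, and compound 3 `CC1=C(C(=O)OC(C)(C)C)C(c2ccsc2)NC(=O)N1C` gives 35%. The two measured steps are a number 3 percentage points lower from compound 1 to compound 2 (within the scatter) and a number 12 percentage points lower from compound 1 to compound 3 (beyond the scatter). Compound 4 `CC1=C(C(=O)NC(C)C)C(c2ccsc2)NC(=O)N1` differs from compound 1 by isopropylamino in place of tert-butoxy on a carbonyl carbon. Going by the values given here, only the step from compound 1 to compound 2 concerns the group on the carbonyl carbon, and there exchanging one oxygen-linked group for another changed little. Swapping tert-butoxy for isopropylamino, which brings a hydrogen-bond donor in place of an acceptor, is a larger change with no measured counterpart, so uncertainty is wide. For compound 4 a modest decrease is expected, a number 12 percentage points lower from compound 1 to compound 4 (beyond the scatter). Compound 4 is estimated at 35%, ranging from 15% to 55%.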

Compound 4, a percentage reported as inhibition, at one concentration (the size of the read-out at that concentration, not a potency): 3%
For compound 4 the middle estimate is 32 percentage points above the measured one; measured number outside the range, below it.
By their numbers in this assay, from the lowest: compound 4; then compounds 3, 2 and 1 (each within the scatter of the next, the first and the last beyond it).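

Going by these compounds alone, at this position the nature of the link to the carbonyl carbon matters far more than the earlier compounds suggested: in this assay, isopropylamino in place of tert-butoxy gives a number 44 percentage points lower from compound 1 to compound 4 (beyond the scatter), whereas benzyl in place of tert-butyl on the oxygen gives only a number 3 percentage points lower from compound 1 to compound 2 (within the scatter). Of the changes shown, this is the only one that replaces the oxygen link, and it nearly abolishes the read-out. Nothing available accounts for this loss. As far as these compounds go, whether it follows the nitrogen link or the isopropyl group remains open, and tert-butylamino on the same carbonyl carbon would separate the two. From the compounds shown here alone, how a carboxylic acid would read there is also open.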